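This account rests on a few compounds, and the source may have more. Where it says the series, first, only, none or still open, it means among the compounds named here.

Of the compounds shown here, three sharing one core have so far been tested in an assay on cells for displacement of a labelled ligand from Glucagon receptor (Homo sapiens), in the presence of a further agent that is not named here; a higher number here means a weaker inhibitor, a lower number a stronger inhibitor. Compound 1 `CCCC(Oc1ccc(-n2cc(OC)cn2)cc1)c1ccc(C(=O)NCCC(=O)O)cc1` gives 4400 nM in this assay. Compound 2 `CCCC(Oc1ccc(-n2cc(C(=O)N(C)C)cn2)cc1)c1ccc(C(=O)NCCC(=O)O)cc1` gives 6500 nM in this assay. Among the measured compounds shown here, the single step between neighbours that differ in one place, a 1.5-fold higher number from compound 1 to compound 2 (0.17 log units; within the scatter), stays within the scatter, so these two numbers cannot be told apart. Compound 3 `O=C(O)CCNC(=O)c1ccc(C(Oc2ccc(-n3cc(C(F)(F)F)cn3)cc2)C2CCC2)cc1` gives 700 nM in this assay, the lowest of the three numbers; its gap to compound 1 and its gap to compound 2 both lie beyond the scatter.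

Compound 4 `O=C(O)CCNC(=O)c1ccc(C(Oc2ccc(-n3cc(C(F)(F)F)cn3)cc2)C2CCCC2)cc1` has not yet been measured. It differs from compound 3 in one place: cyclopentyl in place of cyclobutyl on a saturated chain carbon bound to an aromatic carbon and an oxygen on an aromatic ring. For the measured compounds named here, none of the measured steps touches that place; the only measured step concerns a different part of the molecule and was itself within the scatter. Going by the values given here, there is therefore no measured precedent for a shift in either direction, and the safest expectation is a step not larger than the scatter. The expected step is therefore a 1.3-fold lower number from compound 3 to compound 4 (0.10 log units; within the scatter), with no clear direction. Compound 4 is accordingly estimated at 550 nM in this assay, within a range from 150 nM to 2000 nM.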

Compound 4, inhibition constant: 420 nM
Compound 4: middle estimate off by 1.3-fold (0.12 log units), on the high side, within the range that was stated.
By their numbers in this assay, from the lowest: compounds 4 and 3 (each within the scatter of the next); then compounds 1 and 2 (each within the scatter of the next).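

Swapping cyclobutyl for cyclopentyl on the saturated chain carbon bound to an aromatic carbon and an oxygen on an aromatic ring gives a 1.7-fold lower number from compound 3 to compound 4 (0.22 log units; within the scatter) in this assay. Among the compounds shown here, this is the first measured step at this place, and it shows that a five-membered ring of carbon can stand in for a four-membered one with no readable difference in this assay, so the two numbers have to be treated as the same. For the compounds shown here, the single pair gives a first look at this place, and nothing measured alongside it offers an explanation for how little the number moves.

Going by these compounds, what stays open is how far this tolerance reaches, since only these two ring sizes can be compared directly at this carbon: a cyclopropyl or a cyclohexyl ring could stay within the scatter of these two compounds or fall well outside it. On these data alone, it is also open whether a ring carrying a hydroxyl group or an amine, or an open chain such as isobutyl, would behave like the plain carbon rings seen in compound 3 and compound 4.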